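A few compounds are considered here, and "the series" means these few. Any claim that something is new, unique, unknown or untested is made for them only; others in the source may bear on it.

In a functional assay on HUVEC cells (Homo sapiens) for inhibition (on this read-out lower numbers stand for stronger inhibition and higher numbers for weaker inhibition), compound 1 (`CN(c1ccc(NC(=N)Nc2ccccc2)cc1)c1ccnc(Nc2cccc(CS(C)(=O)=O)c2)n1`) reads 596 nM and compound 2 (`CC(=O)c1ccc(NC(=O)Nc2ccc(N(C)c3ccnc(Nc4cccc(CS(C)(=O)=O)c4)n3)cc2)cc1`) reads 2 nM while compound 3 (`CN(c1ccc(NC(=O)Nc2ccc(OC(F)(F)F)cc2)cc1)c1ccnc(Nc2cccc(CS(C)(=O)=O)c2)n1`) reads 7 nM in the middle of the three. Compound 4 (`CCNC(=O)Nc1ccc(N(C)c2ccnc(Nc3cccc(CS(C)(=O)=O)c3)n2)cc1`) has ethyl in place of 4-(trifluoromethoxy)phenyl on an amide-type nitrogen. Among the measured compounds shown here, two measured steps bear on this change. Putting trifluoromethoxy in place of acetyl on an aromatic carbon made a modest difference (a 3.5-fold higher number from compound 2 to compound 3 (0.54 log units; beyond the scatter)) while exchanging a whole group on a nitrogen made a large one (a 300-fold lower number from compound 1 to compound 2 (2.47 log units; beyond the scatter)). For the measured compounds named here, no measured compound carries ethyl there, so the size remains uncertain. A clearly higher number is expected in this assay with an estimated step between those two sizes (an 11-fold higher number from compound 3 to compound 4 (1.06 log units; beyond the scatter)). Compound 4 is expected at 80 nM with an estimated range from 15 nM to 400 nM as its limits.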

Compound 4, half-maximal inhibitory concentration: 3 nM
Estimate against measurement, compound 4: 27-fold (1.43 log units) above, and the stated range ends above it.
By their numbers in this assay, from the lowest: compounds 2 and 4 (each within the scatter of the next); then compound 3; then compound 1.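

The ring on the amide-type nitrogen turns out not to be needed in this assay: ethyl, with no ring at all, does better than 4-(trifluoromethoxy)phenyl (a 2.3-fold lower number from compound 3 to compound 4 (0.37 log units; beyond the scatter)) and is level with 4-acetylphenyl (a 1.5-fold higher number from compound 2 to compound 4 (0.18 log units; within the scatter)). This small group also keeps nearly all of the large gain over the group of compound 1 (a 200-fold lower number from compound 1 to compound 4 (2.30 log units; beyond the scatter)). Nothing available explains why the ring can go.

Still open, going by these compounds, is how a methyl group, a longer chain such as butyl, or a carboxylic acid on the chain would read at this nitrogen.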